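Moving the Sulfamoyl Group Out on a Two-Carbon Chain

The source may report more compounds than this note shows. Statements on the series, on what has been measured and on what is new or still open speak of the compounds shown alone.

Three measured compounds share one core and differ only in the group attached to a nitrogen on the aromatic ring. Compound 1 `CS(=O)(=O)NNc1nonc1/C(=N/O)Nc1ccc(F)c(Br)c1` carries a methanesulfonamido group, compound 2 `NS(=O)(=O)NNc1nonc1/C(=N/O)Nc1ccc(F)c(Br)c1` a sulfamoylamino group, and compound 3 `CCNS(=O)(=O)CCNc1nonc1/C(=N/O)Nc1ccc(F)c(Br)c1` a 2-(ethylsulfamoyl)ethyl chain. In an assay on isolated protein for inhibition of Indoleamine 2,3-dioxygenase 1 (Homo sapiens), read by fluorescence, with a stated time of 60 min (a higher number here means a weaker inhibitor, a lower number a stronger inhibitor), compound 1 gives 609 nM, compound 2 gives 218 nM, and compound 3 gives 95 nM. Compound 2 sits in the middle: the change a 2.8-fold lower number from compound 1 to compound 2 (0.45 log units; beyond the scatter) lies on one side, and a 2.3-fold lower number from compound 2 to compound 3 (0.36 log units; beyond the scatter) on the other, so compound 2 is neither the strongest nor the weakest of the three.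

Compound 4 `NS(=O)(=O)CCONc1nonc1/C(=N/O)Nc1ccc(F)c(Br)c1` is not yet measured. It differs from compound 2 in one place: 2-sulfamoylethoxy in place of sulfamoylamino on a nitrogen on an aromatic ring

Among the compounds with values here, the steps that bear on this are a 2.3-fold lower number from compound 2 to compound 3 (0.36 log units; beyond the scatter) and a 6.4-fold lower number from compound 1 to compound 3 (0.81 log units; beyond the scatter), both of which place the sulfur at the end of a two-carbon chain on that nitrogen and both of which lowered the number. Within the data shown here, compound 4 makes a similar move, though through an oxygen link that no measured compound shows, so the outcome is less certain. A modest lowering is therefore expected for compound 4, estimated as a 1.8-fold lower number from compound 2 to compound 4 (0.26 log units; within the scatter). Compound 4 is expected to give about 120 nM in this assay, within a range of 50 nM to 350 nM.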

Compound 4, half-maximal inhibitory concentration: 87 nM
For compound 4 the middle estimate is 1.4-fold (0.14 log units) above the measured one, and the stated range covers the measured number.
By their numbers in this assay, from the lowest: compounds 4 and 3 (each within the scatter of the next); then compound 2; then compound 1.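

In this assay, within the data shown here, the step of a 2.5-fold lower number from compound 2 to compound 4 (0.40 log units; beyond the scatter) shows that placing the sulfur at the end of a chain on this nitrogen still lowers the number when an oxygen forms the link, something no earlier compound could show, and the larger step of a 7.0-fold lower number from compound 1 to compound 4 (0.85 log units; beyond the scatter) points the same way. The step of a 1.1-fold lower number from compound 3 to compound 4 (0.04 log units; within the scatter) means that 2-sulfamoylethoxy and 2-(ethylsulfamoyl)ethyl cannot be told apart here, although they differ both in the oxygen link and in the ethyl on the sulfamoyl nitrogen, so neither feature can be credited or blamed alone. No measurement on hand explains why the number moves with these changes at this position.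

On these data alone, the separate contributions of the oxygen link and the ethyl remain open, and a plain 2-sulfamoylethyl chain and a 2-(ethylsulfamoyl)ethoxy group would be the natural pair for separating them. Also open, as far as these compounds go, is whether a longer chain, or a carboxylic acid in place of the sulfamoyl end, would keep the number as low as in compound 3 and compound 4.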